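The source may report more compounds than this note shows. Statements on the series, on what has been measured and on what is new or still open speak of the compounds shown alone.

Measured so far:
compound 1 (`NS(=O)(=O)c1cc2cc(Cl)ccc2oc1=O`): 29100 nM
compound 2 (`NS(=O)(=O)c1cc2cc(Br)ccc2oc1=O`): 24700 nM

Within the data shown here, in a functional assay on A-431 cells (Homo sapiens) for antiproliferative activity, read by MTT assay, with a stated time of 48 h (on this read-out higher numbers stand for weaker inhibition and lower numbers for stronger inhibition), compound 1 holds one of only two numbers, level with compound 2 within the scatter. Compound 3 (`NS(=O)(=O)c1cc2cc(Cl)cc(Cl)c2oc1=O`) keeps the core of compound 1 and has chloro in place of hydrogen on an aromatic carbon. Among the measured compounds shown here, the one measured step (a 1.2-fold lower number from compound 1 to compound 2 (0.07 log units; within the scatter)) puts bromo in place of chloro and stays within the scatter, so it gives only weak guidance on an added chloro. A small move towards a lower number is expected, with the estimated step being a 1.5-fold lower number from compound 1 to compound 3 (0.19 log units; within the scatter) at most likely. In this assay compound 3 is expected at 19000 nM with an estimated range between 8000 nM and 42000 nM overall.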

Compound 3, half-maximal inhibitory concentration: 20300 nM
The estimate for compound 3 lay 1.1-fold (0.03 log units) below the measured number; measured number inside the range.
By their numbers in this assay, from the lowest: compounds 3, 2 and 1 (each within the scatter of the next).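

In this assay, a second chloro on the aromatic carbon ortho to a fused ring and meta to a chloro group gives a 1.4-fold lower number from compound 1 to compound 3 (0.16 log units; within the scatter) and so stays within the scatter. The earlier pair only exchanged one halogen for another, whereas this result shows that this hydrogen can give way to chloro with no clear shift in the number. Nothing available explains this result.

Going by these compounds, whether an amine or a methoxy group on the same carbon would also leave the number within the scatter remains open.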